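The source may report more compounds than this note shows. Statements on the series, on what has been measured and on what is new or still open speak of the compounds shown alone.

Measured so far:
- Compound 1 `COc1ccc(-n2cc(COc3ccc(/C=C/C(=O)c4cc5c(cc4O)OC(C)(C)CC5)cc3)nn2)c([N+](=O)[O-])c1` — in a functional assay on HepG2 cells (Homo sapiens) for antiproliferative activity, read by MTT assay (on this read-out lower numbers stand for stronger inhibition and higher numbers for weaker inhibition), compound 1 gives "not active" (no number reported).
- Compound 2 `Cc1ccc(-n2cc(COc3ccc(/C=C/C(=O)c4ccc5c(c4O)CCC(C)(C)O5)cc3)nn2)cc1Br` — in this assay compound 2 gives 110000 nM.

Compound 1 has no single number in this assay: it is simply reported as not active, so it offers no fixed point from which a step could be measured. Going by the values given here, compound 2, which shares the broad shape of compound 1 but differs in more than one place, gives a weak value, and no step between the two is computed, so the two values only show that both compounds sit at the weak end of the scale.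

Compound 3 `CCCCCn1cc(COc2ccc(/C=C/C(=O)c3cc4c(cc3O)OC(C)(C)CC4)cc2)nn1` is the next compound to be tested. It differs from compound 1 in a single place: pentyl in place of 4-methoxy-2-nitrophenyl on an aromatic nitrogen. Among the compounds with values here, with compound 1 lacking a number, no step can be computed for this change, and the size of its effect in this assay is open. Given that both measured compounds are weak, the expectation is for compound 3 to remain in the weak range, with a fair chance that only a limit is reported. Compound 3 is estimated at about 100000 nM, likely between 30000 nM and 300000 nM.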

Compound 3, half-maximal inhibitory concentration: 95800 nM
Estimate against measurement, compound 3: 1.0-fold (0.02 log units) above; the measured number falls inside the stated range.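

In this assay, going by these compounds alone, compound 3 gives 95800 nM while compound 1 gives "not active" (no number reported) and carries no number, so no step between these two compounds can be read. The compounds shown leave open how much replacing 4-methoxy-2-nitrophenyl with pentyl changes activity. Nothing shown here offers an explanation for either result.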